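Serine amides: metabolic stability in human liver microsomes

The source may report more compounds than this note shows. Statements on the series, on what has been measured and on what is new or still open speak of the compounds shown alone.

Measured compounds:
compound 1, `CC(C)(O)C(=O)N[C@@H](CO)C(=O)O` — "not determined" (no result reported)
compound 2, `C=C(C)C(=O)N[C@@H](CO)C(=O)O` — 82%

In an ADME assay on microsomes from liver (Homo sapiens) for metabolic stability, with a stated time of 30 min (on this read-out higher numbers stand for a more stable compound and lower numbers for a less stable compound), compound 2 gives 82% and stands as the only number shown, since compound 1 has no reported result. Compound 3, `CN(C)C(=O)N[C@@H](CO)C(=O)O`, differs from compound 2 by dimethylamino in place of 1-methylethenyl on a carbonyl carbon. Within the data shown here, no step between two measured compounds is available to set a scale for this change. The expected step of a number 2 percentage points higher from compound 2 to compound 3 (within the scatter) is therefore taken as none beyond the usual scatter. Compound 3 is estimated at 84%, with a range from 66% to 98%.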

Compound 3, percent of the compound remaining: 34%
Compound 3: the middle estimate sits 50 percentage points above what was measured, outside the stated range (below it).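

At this place, on a carbonyl carbon whose other neighbour is the amide-type nitrogen, the read-out in this assay depends on the group: dimethylamino in place of 1-methylethenyl gives a number 48 percentage points lower from compound 2 to compound 3 (beyond the scatter) in a single change. Both groups count the same number of heavy atoms, so that count alone does not fix the read-out here. Nothing in the data at hand gives a reason for the step.

Open, from the compounds shown here alone, is whether methylamino on the same carbonyl carbon stays near compound 3 or compound 2. Open too, going by these compounds, is where a longer chain such as propyl would fall.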